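Taking the methyl group off compound 2

The source may hold more compounds than are shown below. What is called first, only, known or untested is meant among the compounds shown, and "the series" means these compounds.

Measured in an ADME assay on microsomes from liver (Mus musculus) for metabolic stability, read by LC-MS, using NADPH, with a stated time of 60 min, tested at 1 uM; a lower number here means that the compound disappears faster, a higher number that the compound lasts longer:
compound 1 `COc1ccc(-n2c(N)nc3ccccc32)c(O)c1`: 0.1 h
compound 2 `Cc1ccc(-n2c(N)nc3ccccc32)c(O)c1`: 0.3 h

Of the two measured compounds, compound 2 holds the higher number, at 0.3 h, and compound 1 lies below it by a gap beyond the scatter. The next structure, compound 3 `Nc1nc2ccccc2n1-c1ccccc1O`, has not yet been measured. It differs from compound 2 by a single change, hydrogen in place of methyl on an aromatic carbon, meta to a hydroxy group and para to a large group.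

Among the measured compounds shown here, only one measured step bears on this, the modest 3.0-fold higher number from compound 1 to compound 2 (0.48 log units; beyond the scatter), which put methyl in place of methoxy on that same carbon. For the measured compounds named here, no measured compound carries hydrogen there, so the data favour no direction. Going by that one step, a change no larger than modest is expected in this assay, and quite possibly none beyond the scatter. The estimated step is no change at the digits printed from compound 2 to compound 3 (within the scatter). Compound 3 is expected at about 0.3 h, within an estimated range from 0.12 h to 0.8 h.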

Compound 3, half-life in the Mus musculus assay: 1.3 h
For compound 3 the middle estimate is 4.3-fold (0.64 log units) below the measured one; measured number outside the range, above it.
By their numbers in the Mus musculus assay, from the lowest: compound 1; then compound 2; then compound 3.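

In the Mus musculus assay the aromatic carbon meta to a hydroxy group and para to a large group now shows a clear response to what it carries, with a 4.3-fold higher number from compound 2 to compound 3 (0.64 log units; beyond the scatter) and a 13-fold higher number from compound 1 to compound 3 (1.11 log units; beyond the scatter). The earlier pair showed only that methyl gave a longer half-life than methoxy on this carbon, whereas the three compounds now run in the order methoxy, methyl, hydrogen, and none of them goes against it, so the compound with no substituent there lasts longest of the three. Nothing among the measurements shown accounts for this rise in half-life.

In a physicochemical assay for solubility, read by nephelometry, measured as kinetic solubility, with a stated time of 30 min, at pH 2 (a lower number here means a less soluble compound, a higher number a more soluble compound), compound 2 gives > 100 ug/mL, which is a limit of the assay and not a number. In the physicochemical assay compound 3 gives > 100 ug/mL, which is also a limit of the assay and not a number. In the physicochemical assay the step between compound 2 and compound 3 cannot be read, as both values are limits and not numbers: the limit of > 100 ug/mL in the physicochemical assay, at which 2 of the 2 values shown sit. Still open, as far as these compounds go, is whether other groups on this carbon, such as fluorine, chlorine or an ethyl chain, would fit the same order, and whether replacing methyl with hydrogen would have a similar effect on a core with a different substituent elsewhere.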